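Moving a Methyl Around the Phenyl Ring

This account rests on a few compounds, and the source may have more. Where it says the series, first, only, none or still open, it means among the compounds named here.

In an ADME assay on Huh-7 cells (Homo sapiens) for cytotoxicity (on this read-out higher numbers stand for lower toxicity in this test and lower numbers for higher toxicity in this test), compound 1, `CN1CCN(CCNCc2cn(-c3ccc(F)cc3F)nc2Cc2ccccc2)CC1`, gives > 20000 nM, which is a limit of the test rather than a number.
In this assay compound 2, `Cc1ccccc1-c1nn(-c2ccc(F)cc2F)cc1CNCCN1CCN(C)CC1`, gives > 20000 nM, again a limit rather than a number.

Compound 2 therefore stands at the limit of > 20000 nM in this assay, at which 2 of the 2 values shown sit. For the measured compounds named here, the only measured step, a step that the two limits leave unreadable from compound 1 to compound 2, cannot be read, because both ends are limits.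

Compound 3, `Cc1ccc(-c2nn(-c3ccc(F)cc3F)cc2CNCCN2CCN(C)CC2)cc1`, differs from compound 2 in one place: 4-methylphenyl in place of 2-methylphenyl on an aromatic carbon. Going by the values given here, no measured step bears on this change, and the single step that is known gives no size. The expectation is that compound 3 also reaches the limit in this assay. The change is expected to amount to a number no higher from compound 2 to compound 3 (the limit leaves the size open), nothing beyond the usual scatter. Compound 3 is expected to give 20000 nM, in the range from 10000 nM to 40000 nM.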

Compound 3, half-maximal cytotoxic concentration: > 20000 nM
Compound 3: only a limit was reported (the forecaster's own chance of this, stated with the estimate: 85%); the middle value sits exactly at the limit.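

The steps among compound 1, compound 2 and compound 3 cannot be read, since each compound stops at a limit of the test rather than a number: the limit of > 20000 nM in this assay, at which 3 of the 3 values shown sit.

The compounds shown leave open whether 4-methylphenyl, 2-methylphenyl and benzyl differ at all in this assay.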